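The source may hold more compounds than are shown below. What is called first, only, known or untested is meant among the compounds shown, and "the series" means these compounds.

Measured so far in a functional assay on PC-3 cells (Homo sapiens) for inhibition, read by MTT assay, with a stated time of 48 h; on this read-out lower numbers stand for stronger inhibition and higher numbers for weaker inhibition:

compound 1 `O=C(/C=C/c1cccc([N+](=O)[O-])c1)c1ccc[nH]1` gives 23000 nM
compound 2 `O=C(/C=C/c1cc([N+](=O)[O-])ccc1Cl)c1ccc[nH]1` gives 55000 nM
compound 3 `O=C(/C=C/c1ccc(Br)cc1)c1ccc[nH]1` gives 44000 nM

Compound 2 stands at the highest of the three numbers in this assay, though compound 3 sits within the usual scatter of it; the only separation beyond the scatter is a 2.4-fold higher number from compound 1 to compound 2 (0.38 log units; beyond the scatter), a modest step that comes with chloro in place of hydrogen on an aromatic carbon.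

The next compound, compound 4 `O=C(/C=C/c1cc([N+](=O)[O-])ccc1Cl)c1ccco1`, keeps the whole of compound 2 apart from one change: furan-2-yl in place of 1H-pyrrol-2-yl on a carbonyl carbon. Among the compounds with values here, no measured pair exchanges the ring on the carbonyl carbon, so no measured step bears directly on this change; the step already seen concerns a substituent on the other aromatic ring and says nothing about the carbonyl side. With nothing to point either way, the expectation is a step in this assay of no more than the scatter, with the range left wide to allow for a shift in either direction, estimated as a 1.2-fold higher number from compound 2 to compound 4 (0.07 log units; within the scatter).

Compound 4 is therefore expected to give about 65000 nM, within a range of 22000 nM to 190000 nM.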

Compound 4, half-maximal inhibitory concentration: 62000 nM
Compound 4: middle estimate off by 1.0-fold (0.02 log units), on the high side; the range from low to high includes it.
By their numbers in this assay, from the lowest: compounds 1, 3, 2 and 4 (each within the scatter of the next, the first and the last beyond it).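

In this assay, within the data shown here, the first reading on the carbonyl side of the series is a 1.1-fold higher number from compound 2 to compound 4 (0.05 log units; within the scatter) for furan-2-yl in place of 1H-pyrrol-2-yl on a carbonyl carbon. Among these compounds, the earlier step concerned only the other aromatic ring, so this is the first sign that the carbonyl position can take a different five-membered aromatic ring without a shift beyond the scatter, at least with the substituents of compound 2. The hydrogen-bond donor counted on 1H-pyrrol-2-yl leaves and a hydrogen-bond acceptor enters with furan-2-yl, and no measurement at hand gives a reason for the result.

From the compounds shown here alone, whether furan-2-yl behaves the same way with the other aromatic ring of compound 1 or compound 3 remains open. Also open, going by these compounds, is whether thiophen-2-yl, or a phenyl ring carrying an amine, on the carbonyl carbon would move the number beyond the scatter.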